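This account rests on a few compounds, and the source may have more. Where it says the series, first, only, none or still open, it means among the compounds named here.

Of the compounds shown here, three have been measured. Compound 1 `c1ccc2c(-c3cn4ccnc4c(-c4ccc5ncn(C6CCCCC6)c5c4)n3)cccc2c1` and compound 2 `Fc1ccccc1-c1cn2ccnc2c(-c2ccc3ncn(C4CCCCC4)c3c2)n1` share one core and differ in a single group, while compound 3 `c1cn2cc(-c3ccc4c(c3)ncn4C3CCCCC3)nc(-c3ccc4ncn(C5CCCCC5)c4c3)c2n1` carries the same core on both sides. In a functional assay on NCI-H460 cells (Homo sapiens) for inhibition, read by sulforhodamine B assay, with a stated time of 48 h, tested at 10 uM (on this read-out higher numbers stand for more inhibition at the one concentration tested (going by the name of the read-out) and lower numbers for less inhibition), compound 1 gives 3.61%. Going by the values given here, in the same this assay compound 2 gives 8.1%, and the only step between compounds differing in one place, a number 4.5 percentage points higher from compound 1 to compound 2 (within the scatter), came with 2-fluorophenyl in place of naphthalen-1-yl on an aromatic carbon. Compound 3 gives 11.9% in this assay. Its number is the highest of the three, but it lies within the scatter of both compound 2 and compound 1, so no order among them can be claimed; all three sit at the low end of the read-out.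

Compound 4 `c1ccc(Cn2cnc3ccc(-c4nc(-c5ccc6c(c5)ncn6C5CCCCC5)cn5ccnc45)cc32)cc1` is not yet measured. It differs from compound 3 in one place: benzyl in place of cyclohexyl on an aromatic nitrogen. Among the compounds with values here, no measured step bears on a change at this aromatic nitrogen; the one step recorded concerns a different position and was itself within the scatter. Nothing here points to a move beyond the scatter in either direction.

Compound 4 is therefore expected to give about 10%, in a range from 0% to 25%. The step this estimate implies, a number 1.9 percentage points lower from compound 3 to compound 4 (within the scatter), is expected to stay within the scatter.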

Compound 4, a percentage reported as inhibition, at one concentration (the size of the read-out at that concentration, not a potency): -20.3%
Estimate against measurement, compound 4: 30.3 percentage points above, outside the stated range (below it).
By their numbers in this assay, from the lowest: compound 4; then compounds 1, 2 and 3 (each within the scatter of the next).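

Going by these compounds alone, the aromatic nitrogen of the five-membered ring proves to be a position to which this read-out responds: with benzyl in place of cyclohexyl there is a number 32.2 percentage points lower from compound 3 to compound 4 (beyond the scatter) in this assay and this is the first step to go beyond the scatter. Neither group carries a hydrogen-bond donor, a hydrogen-bond acceptor or a net charge, and what the exchange visibly alters is a six-membered non-aromatic ring of carbon giving way to an aromatic one within benzyl. Within the data shown here, this single exchange takes compound 4 to -20.3% in this assay and so to a negative figure, whereas the earlier compounds all gave low positive numbers. No measurement available here accounts for the drop, which rests on this one pair of compounds.

The compounds shown leave open whether the drop belongs to benzyl itself or to the loss of cyclohexyl, and whether the same exchange on the other side of the core, where compound 4 keeps cyclohexyl, would read alike. They also leave open how a methyl group, a phenethyl group, a longer chain ending in an amine or a carboxylic acid would read on this nitrogen.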